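The source may report more compounds than this note shows. Statements on the series, on what has been measured and on what is new or still open speak of the compounds shown alone.

Measured in a functional assay on the whole organism for inhibition, with Brassica rapa subsp. chinensis as the target, with a stated time of 3 days, tested at 100 ppm; on this read-out higher numbers stand for more inhibition of growth at the one concentration tested and lower numbers for less inhibition of growth:
- compound 1 `CCCNC(=O)/C=C/c1ccccc1`: 63%
- compound 2 `CC(C)CNC(=O)/C=C/c1ccccc1`: 78%

Compound 2 stands highest of the two measured compounds, beyond the scatter of compound 1. The next compound is compound 3 `C=CCNC(=O)/C=C/c1ccccc1`. It differs from compound 2 by one change: vinyl in place of isopropyl on a saturated chain carbon bound to an amide-type nitrogen. In words, this is vinyl in place of isopropyl on a saturated chain carbon bound to an amide-type nitrogen, so isobutyl becomes allyl. Within the data shown here, only one measured step bears on this, a number 15 percentage points higher from compound 1 to compound 2 (beyond the scatter), which was a modest change on the same chain. The isopropyl that leaves holds the methyl gained in that step, so a fall of similar size is expected in this assay, an estimated a number 15 percentage points lower from compound 2 to compound 3 (beyond the scatter). For compound 3 the expected value is 63%, within an estimated range of 45% to 80%.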

Compound 3, percent growth inhibition at one concentration: 64%
Compound 3: middle estimate off by 1 percentage points, on the low side, and the stated range covers the measured number.
By their numbers in this assay, from the lowest: compounds 1 and 3 (each within the scatter of the next); then compound 2.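

Vinyl in place of isopropyl on a saturated chain carbon bound to an amide-type nitrogen gives a number 14 percentage points lower from compound 2 to compound 3 (beyond the scatter) in this assay and so removes the advantage of compound 2. Vinyl in place of ethyl at that carbon gives a number 1 percentage points higher from compound 1 to compound 3 (within the scatter) and so leaves allyl level with the parent chain of compound 1 on this read-out. Nothing measured here accounts for these numbers. On these data alone, whether a longer chain or a tert-butyl group at this place would match or pass compound 2 remains open.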